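Fluoro in place of chloro on compound 1

The compounds below may be only part of what the source reports. "The series", "measured", "known", "first", "only" and "open" are said of these compounds alone.

Measured so far (a physicochemical assay for solubility, read by HPLC, in phosphate buffer, measured as kinetic solubility, at pH 7.4; on this read-out lower numbers stand for lower solubility and higher numbers for higher solubility):
- Compound 1 (`CCC(=O)c1cc(-c2ccc(S(N)(=O)=O)cc2)n(-c2ccc(Cl)cc2)n1`) gives 41900 nM
- Compound 2 (`CC(C)(C)C(=O)c1cc(-c2ccc(S(N)(=O)=O)cc2)n(-c2ccc(Cl)cc2)n1`) gives 6600 nM

Among the compounds with values here, compound 1 holds the higher of these two numbers, and the only measured step away from it goes down (a 6.3-fold lower number from compound 1 to compound 2 (0.80 log units; beyond the scatter)). That step puts tert-butyl in place of ethyl on a carbonyl carbon.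

The next compound, compound 3 (`CCC(=O)c1cc(-c2ccc(S(N)(=O)=O)cc2)n(-c2ccc(F)cc2)n1`), differs from compound 1 at a different place (fluoro in place of chloro on an aromatic carbon). It has fluoro in place of chloro on an aromatic carbon, so 4-chlorophenyl becomes 4-fluorophenyl.

Within the data shown here, no measured pair swaps one halogen for another, so the step to compound 2 bears on this change only loosely. It shows how far a single change can move this read-out, and nothing more. The step expected in this assay is therefore smaller, probably within the usual scatter. It may lean towards a higher number, though the data do not settle the direction.

That expectation amounts to (a 1.4-fold higher number from compound 1 to compound 3 (0.16 log units; within the scatter)). Compound 3 is estimated at 60000 nM (expected range 25000 nM to 130000 nM).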

Compound 3, solubility: 96800 nM
For compound 3 the middle estimate is 1.6-fold (0.21 log units) below the measured one; the measured number falls inside the stated range.
By their numbers in this assay, from the lowest: compound 2; then compound 1; then compound 3.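

In this assay the exchange of 4-chlorophenyl for 4-fluorophenyl comes with a 2.3-fold higher number from compound 1 to compound 3 (0.36 log units; beyond the scatter) and so shows that this aromatic position can also shift the read-out beyond the scatter, even though one heavy atom simply replaces another and the counts of hydrogen-bond donors, hydrogen-bond acceptors and net charge stay the same. Within the data shown here, the only earlier step from compound 1, tert-butyl in place of ethyl on a carbonyl carbon, went down, whereas this one goes up, so compound 1 no longer holds the highest number and changes at two different places now pull in opposite directions. No measurement shown here explains the rise, and its cause remains unknown.

On these data alone, it remains open whether the rise is particular to fluoro or whether a plain hydrogen, a methoxy group or an amine at the same place would give a similar number. As far as these compounds go, it is also open whether fluoro would bring a comparable step on the tert-butyl compound, compound 2, or whether the two changes would not add up in a simple way.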